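Adding a Second Methyl to a Related Core

This account rests on a few compounds, and the source may have more. Where it says the series, first, only, none or still open, it means among the compounds named here.

Of the compounds shown here, three sharing one core have been tested in a functional assay on NCI-H460 cells (Homo sapiens) for cytotoxicity, read by MTT assay, with a stated time of 72 h; a higher number here means a weaker inhibitor, a lower number a stronger inhibitor. Compound 1 `COc1cc2c(Oc3ccc(NC(=O)c4cn(-c5ccccc5C)nn4)cc3F)ccnc2cc1OCCCN1CCCC1` gives 1260 nM in this assay. Compound 2 `COc1cc2c(Oc3ccc(NC(=O)c4cn(-c5c(C)cccc5C)nn4)cc3F)ccnc2cc1OCCCN1CCCC1` carries one further change, (methyl in place of hydrogen on an aromatic carbon), and gives 1560 nM in this assay, so that the change reads as a 1.2-fold higher number from compound 1 to compound 2 (0.09 log units; within the scatter). Compound 3 `COc1cc2c(Oc3ccc(NC(=O)c4cn(-c5ccccc5C)nn4)cc3F)ccnc2cc1OCCCN1CCC(C)CC1` instead gives 2730 nM in this assay, a step of a 2.2-fold higher number from compound 1 to compound 3 (0.34 log units; beyond the scatter).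

Compound 4 `COc1cc2c(Oc3ccc(NC(=O)c4cn(-c5c(C)cccc5C)nn4)cc3F)ccnc2cc1OCCCN1CCC(C)CC1` awaits measurement. Its core differs from that of compound 1 by 4-methylpiperidin-1-yl in place of pyrrolidin-1-yl on a saturated chain carbon, three bonds along the chain from an oxygen on an aromatic ring; on that core, compound 4 differs from compound 3 by methyl in place of hydrogen on an aromatic carbon. The surroundings of the changed position are described in the same words for both pairs, so this is the same change seen once already, now made on the core of compound 3.

Compound 4 is expected to move from compound 3 by about a 1.2-fold higher number from compound 3 to compound 4 (0.07 log units; within the scatter), because the same change earlier gave a 1.2-fold higher number from compound 1 to compound 2 (0.09 log units; within the scatter), a step within the scatter. Compound 4 is therefore estimated at 3200 nM in this assay, with a likely range from 1600 nM to 6500 nM.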

Compound 4, half-maximal inhibitory concentration: 2360 nM
The estimate for compound 4 lay 1.4-fold (0.13 log units) above the measured number; the measured number falls inside the stated range.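

In this assay, going from 2-methylphenyl to 2,6-dimethylphenyl gives a 1.2-fold lower number from compound 3 to compound 4 (0.06 log units; within the scatter), so on both cores this methyl step stays within the scatter, and the two readings agree: the same change on two cores in this assay, a 1.2-fold higher number (0.09 log units; within the scatter) from compound 1 to compound 2 and a 1.2-fold lower number (0.06 log units; within the scatter) from compound 3 to compound 4, 1.4-fold (0.16 log units) apart, within the scatter of two such steps. The other change, 4-methylpiperidin-1-yl in place of pyrrolidin-1-yl, gives a 1.5-fold higher number from compound 2 to compound 4 (0.18 log units; within the scatter); this step is within the scatter while its earlier counterpart lies just beyond it, yet the gap between the two is small enough that they still agree: the same change on two cores in this assay, a 2.2-fold higher number (0.34 log units; beyond the scatter) from compound 1 to compound 3 and a 1.5-fold higher number (0.18 log units; within the scatter) from compound 2 to compound 4, 1.4-fold (0.16 log units) apart, within the scatter of two such steps. This shows that each change read much the same on the two cores here, but it rests on only four compounds, and steps this small cannot separate a slight real effect from ordinary scatter, so it sets no rule for the wider series.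

As far as these compounds go, it remains open whether other groups at the same place on the aromatic ring, such as chloro or ethyl, would carry over in the same way. The same question stands for other amines on the chain, such as morpholin-4-yl or dimethylamino.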